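Notes on compound 1 and a dimethylamino analogue

A few compounds are considered here, and "the series" means these few. Any claim that something is new, unique, unknown or untested is made for them only; others in the source may bear on it.

compound 1 `CCn1nnc(-c2sc(-c3cccc(C)c3)nc2O)n1` — 369 nM
compound 2 `CCOC(=O)c1sc(-c2ccccc2)nc1N` — > 100000 nM
compound 3 `O=C(O)c1sc(-c2ccccc2)nc1O` — > 100000 nM

Going by the values given here, in an assay on HEK293 cells for inhibition of transient receptor potential cation channel subfamily M member 8 (Homo sapiens), read by FLIPR, with stated times of 5 min and 3 min (on this read-out lower numbers stand for stronger inhibition and higher numbers for weaker inhibition), compound 1 gives 369 nM, the only measured number in the set. Compound 2 gives > 100000 nM, which is a limit of the assay and not a number. Compound 3 gives > 100000 nM, again a limit. The two limits sit at the limit of > 100000 nM in this assay, at which 2 of the 3 values shown sit. Among the compounds with values here, compounds 2 and 3 carry a different core from compound 1, and none of the three measured compounds differs from another in a single place, so no measured step is available to calibrate the change considered here.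

The unmeasured analogue is compound 4 `CCn1nnc(-c2sc(-c3cccc(N(C)C)c3)nc2O)n1`. It differs from compound 1 by dimethylamino in place of methyl on an aromatic carbon. Nothing in the measured set speaks to this exchange; the aromatic ring of compound 1 carries only the methyl, and compounds 2 and 3 carry no substituent on their ring at all.

Within the data shown here, with no measured step of this kind, the expectation for the change from compound 1 to compound 4 in this assay is a step of a 1.1-fold higher number from compound 1 to compound 4 (0.04 log units; within the scatter), not beyond the usual scatter, with the range kept wide. For compound 4 the estimated value is 400 nM, expected to fall between 100 nM and 1600 nM.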

Compound 4, half-maximal inhibitory concentration: 4770 nM
Compound 4: the middle estimate sits 12-fold (1.08 log units) below what was measured; the measured number lies above the stated range.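

In this assay, going by these compounds alone, the exchange of methyl for dimethylamino gives a 13-fold higher number from compound 1 to compound 4 (1.11 log units; beyond the scatter), the first step read with the core of compound 1 held fixed. This position, on an aromatic carbon of a six-membered aromatic ring of carbon only and meta to a large group, is thus not indifferent to what it carries, although compound 4 still gives a measured number and not a limit of the assay. What is shown establishes the size of this step but offers no measured property that accounts for it.

The compounds shown leave open whether the step belongs to dimethylamino in particular or would follow from any group with more heavy atoms than methyl, and a single exchange cannot separate the nitrogen from the two added carbons. An ethyl or isopropyl group at this position would speak to the carbon count, while a methoxy group or a primary amine would speak to the atom attached to the ring.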